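The compounds below may be only part of what the source reports. "The series", "measured", "known", "first", "only" and "open" are said of these compounds alone.

For the measured compounds named here, compound 3 `O=C(Nc1cccc(I)c1)C(Cl)Cl` is the only member of this small set with a number. In a functional assay on BGC-823 cells (Homo sapiens) for antiproliferative activity, read by MTT assay, with a stated time of 72 h (on this read-out lower numbers stand for stronger inhibition and higher numbers for weaker inhibition), compound 3 gives 58800 nM, a weak effect. Its two relatives, compound 1 `O=C(Nc1ccccc1)C(Cl)Cl` and compound 2 `O=C(Nc1cccc(F)c1)C(Cl)Cl`, share the same amide core but carry no iodine. In this assay, going by the values given here, compound 1 gives "not determined" (no result reported) and compound 2 gives "not determined" (no result reported), so no step between measured compounds can be drawn. The next compound, compound 4 `O=C(Nc1cccc([N+](=O)[O-])c1)C(Cl)Cl`, differs from compound 3 by nitro in place of iodo on an aromatic carbon. Among the compounds with values here, with no measured step to lean on, only a small change in this assay is expected, not beyond the usual scatter, as a 1.2-fold lower number from compound 3 to compound 4 (0.07 log units; within the scatter). Compound 4 is therefore estimated at 50000 nM, within a range from 15000 nM to 150000 nM.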

Compound 4, half-maximal inhibitory concentration: 123000 nM
Beside the measured number, compound 4's estimate is 2.5-fold (0.39 log units) below it, within the range that was stated.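

Placing nitro instead of iodo on this aromatic carbon gives a 2.1-fold higher number from compound 3 to compound 4 (0.32 log units; beyond the scatter), the first sign in this assay that the group held here can shift the result, although only modestly. The direction is towards weaker inhibition, so this swap offers no gain. Nothing measured on either group explains the change.

For the compounds shown here, two compounds give only one step, so it remains open whether other groups at this carbon would follow the same direction. An amine or a carboxylic acid here could show whether any group gives a number lower than that of compound 3.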